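From Methyl to Aminoethyl on the Amide Nitrogen

The compounds below may be only part of what the source reports. "The series", "measured", "known", "first", "only" and "open" are said of these compounds alone.

Three measured compounds share one core and differ only in the group on an amide-type nitrogen. Compound 1 `O=C(NC1CCN(C2CC2)C1)c1cc(-c2ccc(NS(=O)(=O)c3cccc(Cl)c3Cl)cc2)nc2[nH]ncc12` carries a 1-cyclopropylpyrrolidin-3-yl group there and gives 6 nM in an assay for inhibition of serine/threonine-protein kinase Sgk1 (Homo sapiens), with stated times of 30 min and 60 min, in the presence of a further agent that is not named here; on this read-out higher numbers stand for weaker inhibition and lower numbers for stronger inhibition. Compound 2 `NC(=O)c1cc(-c2ccc(NS(=O)(=O)c3cccc(Cl)c3Cl)cc2)nc2[nH]ncc12` carries hydrogen and in this assay gives 1 nM. Compound 3 `CNC(=O)c1cc(-c2ccc(NS(=O)(=O)c3cccc(Cl)c3Cl)cc2)nc2[nH]ncc12` carries methyl and gives 4 nM in this assay. Its number is the second highest of the three: the step of a 1.5-fold lower number from compound 1 to compound 3 (0.18 log units; within the scatter) lies within the scatter, while a 4.0-fold higher number from compound 2 to compound 3 (0.60 log units; beyond the scatter) lies beyond it.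

Compound 4 `NCCNC(=O)c1cc(-c2ccc(NS(=O)(=O)c3cccc(Cl)c3Cl)cc2)nc2[nH]ncc12` is not yet measured and differs from compound 3 by aminomethyl in place of hydrogen on a saturated chain carbon bound to an amide-type nitrogen. Going by the values given here, two measured steps bear on this. The step of a 4.0-fold higher number from compound 2 to compound 3 (0.60 log units; beyond the scatter) shows that adding a small group to the amide nitrogen raised the number, whereas a 1.5-fold lower number from compound 1 to compound 3 (0.18 log units; within the scatter) and a 6.0-fold lower number from compound 1 to compound 2 (0.78 log units; beyond the scatter) show that a far larger group landed close to methyl. Lengthening the chain is therefore expected to change little. Compound 4 is expected at 4 nM with a range from 1.5 nM to 10 nM in this assay. This estimate means no change at the digits printed from compound 3 to compound 4 (within the scatter) and is expected to stay within the scatter.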

Compound 4, half-maximal inhibitory concentration: < 1 nM
Compound 4: no number, only a limit; the forecaster's own chance of this, stated with the estimate: 0%; at least 4.0-fold (0.60 log units) between middle value and limit.
By their numbers in this assay, from the lowest: compound 2; then compounds 3 and 1 (each within the scatter of the next).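

Compound 4 gives a limit of the assay, not a number: the limit of < 1 nM in this assay, at which 1 of the 4 values shown sits. Even so, aminomethyl in place of hydrogen on a saturated chain carbon bound to an amide-type nitrogen gives an at least 4.0-fold lower number from compound 3 to compound 4 (0.60 log units; beyond the scatter), and 2-aminoethyl in place of 1-cyclopropylpyrrolidin-3-yl gives an at least 6.0-fold lower number from compound 1 to compound 4 (0.77 log units; beyond the scatter), so this position separates 2-aminoethyl from methyl and from the larger group, although those two lie within the scatter of each other. The remaining step is a number no higher from compound 2 to compound 4 (the limit leaves the size open) and cannot be read.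

The compounds shown leave open whether the change follows the terminal amine or the longer chain, a question that an ethyl or 2-hydroxyethyl group on the same nitrogen would address. A 3-aminopropyl chain would show whether the distance of the amine from the amide nitrogen matters.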